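Phthalimide-triazole thioethers against a gastric cancer cell line

The source may report more compounds than this note shows. Statements on the series, on what has been measured and on what is new or still open speak of the compounds shown alone.

Measured compounds:
compound 1 `Cc1nnc(SCc2ccccc2)n1N1C(=O)c2ccccc2C1=O`, > 200000 nM
compound 2 `C=CCSc1nnc(CCC)n1N1C(=O)c2ccccc2C1=O`, > 200000 nM
compound 3 `C#CCSc1nnc(-c2cc(OC)c(OC)c(OC)c2)n1N1C(=O)c2ccccc2C1=O`, > 200000 nM

Of the compounds shown here, three sharing the phthalimide-substituted triazole core have been tested in a functional assay on MKN-45 cells (Homo sapiens) for cytotoxicity, read by MTT assay, with a stated time of 48 h; a lower number here means a stronger inhibitor, a higher number a weaker inhibitor. Compound 1 `Cc1nnc(SCc2ccccc2)n1N1C(=O)c2ccccc2C1=O` gives > 200000 nM, which is a limit of the assay and not a number. Compound 2 `C=CCSc1nnc(CCC)n1N1C(=O)c2ccccc2C1=O` likewise gives > 200000 nM, again only a limit. Compound 3 `C#CCSc1nnc(-c2cc(OC)c(OC)c(OC)c2)n1N1C(=O)c2ccccc2C1=O` gives > 200000 nM, also a limit. Compound 3 therefore stands at the same limit as the other two, and nothing on the numbers shown separates it from them (the limit of > 200000 nM in this assay, at which 3 of the 3 values shown sit).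

Compound 4 `COc1cc(-c2nnc(SCC(=O)c3ccc(F)cc3)n2N2C(=O)c3ccccc3C2=O)cc(OC)c1OC` differs from compound 3 in one place: (4-fluorophenyl)carbonyl in place of ethynyl on a saturated chain carbon bound to a sulfur. The thioether chain thus grows from propargyl to ((4-fluorophenyl)carbonyl)methyl. Within the data shown here, since every measured value sits at the limit, no step between measured compounds can guide the size or direction of this change. The expectation is that compound 4 stays near the limit, with the step from compound 3 to compound 4 estimated at a number no higher from compound 3 to compound 4 (the limit leaves the size open) in this assay, which is not a step beyond the scatter that the data can support. Compound 4 is estimated to give 200000 nM in this assay, within a range from 40000 nM to 600000 nM.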

Compound 4, half-maximal inhibitory concentration: 126000 nM
Compound 4: the middle estimate sits 1.6-fold (0.20 log units) above what was measured; low and high end bracket the measured number.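

In this assay the exchange of ethynyl for (4-fluorophenyl)carbonyl on a saturated chain carbon bound to a sulfur gives an at least 1.5-fold lower number from compound 3 to compound 4 (0.20 log units; that floor lies within the scatter) and so, on its floor alone, the change does not clear the usual scatter of repeated measurements. Compound 3 gives > 200000 nM as a limit and not a number, which leaves the true size of the step unknown: it may be no more than that floor, or it may be larger. What is new is that this place on the thioether chain now carries a compound with a real number, compound 4, whereas every earlier compound gave only a limit: the limit of > 200000 nM in this assay, at which 3 of the 4 values shown sit.

The compounds shown leave open whether the carbonyl, the aromatic ring or the fluorine accounts for the change, since these three enter together in a single step. They also leave open what a plain phenyl carbonyl, a carboxylic acid or an amine would give on the same saturated chain carbon bound to a sulfur, and whether any such group would move the number beyond the scatter.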